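Cytotoxicity notes on the trifluoromethyl to methyl switch

A few compounds are considered here, and "the series" means these few. Any claim that something is new, unique, unknown or untested is made for them only; others in the source may bear on it.

Compound 1 `CC(C)(C#Cc1cc(N(C(=O)[C@H]2CC[C@H](C)CC2)[C@H]2CC[C@H](Oc3ccc(=O)[nH]n3)CC2)c(C(=O)O)s1)C(F)(F)F` and compound 2 `CC(C)N(C(=O)C1CCCCCC1)c1cc(C#CC(C)(C)C)sc1C(=O)O` are the two members of the series measured so far in an ADME assay on MT4 cells (Homo sapiens) for cytotoxicity, with a stated time of 5 days; a higher number here means that more compound is tolerated, a lower number that less compound is tolerated. In this assay compound 1 gives only a limit of the assay, > 20000 nM. In this assay compound 2 likewise gives only a limit, > 20000 nM. Compound 1 thus stands at the top of what the assay reports, and it is not alone there, because of the limit of > 20000 nM in this assay, at which 2 of the 2 values shown sit. For the measured compounds named here, no pair differing in one place has been measured, so no step size is known.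

Compound 3 `CC(C)(C)C#Cc1cc(N(C(=O)[C@H]2CC[C@H](C)CC2)[C@H]2CC[C@H](Oc3ccc(=O)[nH]n3)CC2)c(C(=O)O)s1` is yet to be measured in this assay. It differs from compound 1 in one place: methyl in place of trifluoromethyl on a saturated chain carbon bound to two saturated chain carbons and a triple-bonded carbon. Put another way, 1-methyl-1-(trifluoromethyl)ethyl becomes tert-butyl, so the 3-methyl-3-(trifluoromethyl)but-1-yn-1-yl chain becomes 3,3-dimethylbut-1-yn-1-yl. With both measured compounds at the limit, the step expected in this assay is a number no higher from compound 1 to compound 3 (the limit leaves the size open), nothing beyond the scatter. Compound 3 is therefore expected to give 20000 nM in this assay, with a range from 10000 nM to 40000 nM, most likely again reported only as a limit.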

Compound 3, half-maximal cytotoxic concentration: > 20000 nM
Compound 3 was reported as a limit; the forecaster's own chance of this, stated with the estimate: 80%; the middle value sits exactly at the limit.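

In this assay compound 1 and compound 3 both give only a limit, so no step can be read for methyl in place of trifluoromethyl. Compound 1, compound 2 and compound 3 share one limit: the limit of > 20000 nM in this assay, at which 3 of the 3 values shown sit.

The compounds shown leave open whether this change alters tolerance at concentrations beyond that limit.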